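Losing the ethoxy group from compound 3

A few compounds are considered here, and "the series" means these few. Any claim that something is new, unique, unknown or untested is made for them only; others in the source may bear on it.

Among the measured compounds shown here, in a functional assay on MT4 cells (Homo sapiens) for cytotoxicity (a lower number here means a stronger inhibitor, a higher number a weaker inhibitor), compound 3 `CCOc1cc(C)cc(S(=O)(=O)c2cccc(N)c2C#N)c1` gives 9000 nM, the lowest of the three numbers known so far. Compound 1 `N#Cc1c(N)cccc1Sc1ccccc1Br` gives 41000 nM and compound 2 `N#Cc1c(N)cccc1Sc1cccc(N)c1` gives 168000 nM, both higher by more than the scatter. Compound 4 `Cc1cccc(S(=O)(=O)c2cccc(N)c2C#N)c1` differs from compound 3 at one place: hydrogen in place of ethoxy on an aromatic carbon. For the measured compounds named here, no measured pair shows this change on its own, so any forecast is uncertain. With compound 3 at 9000 nM, already the lowest number, a moderate move to a higher number, beyond the scatter, is expected. The estimated step is a 3.3-fold higher number from compound 3 to compound 4 (0.52 log units; beyond the scatter). For compound 4 the estimated value is 30000 nM, with an expected range of 9000 nM to 100000 nM.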

Compound 4, half-maximal inhibitory concentration: 179000 nM
Beside the measured number, compound 4's estimate is 6.0-fold (0.78 log units) below it; measured number above the stated range.
By their numbers in this assay, from the lowest: compound 3; then compound 1; then compounds 2 and 4 (each within the scatter of the next).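

In this assay, replacing ethoxy with hydrogen on this aromatic carbon gives a 20-fold higher number from compound 3 to compound 4 (1.30 log units; beyond the scatter), the first change in one place alone among the compounds shown. It shows that the number depends strongly on what stands at this position, meta to a large group and meta to a methyl group. Nothing at hand explains the size of this step. Still open, on these data alone, is whether a methoxy group, a hydroxyl group or a longer alkoxy chain at this position would keep the lower number. As far as these compounds go, the part played by the methyl group, present in both compounds, also remains open.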